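Swapping a vinyl for a cyclobutylcarbamoyl on the chain

The source may report more compounds than this note shows. Statements on the series, on what has been measured and on what is new or still open speak of the compounds shown alone.

Three compounds share one core and differ in the group hanging from a saturated chain carbon bound to a saturated ring carbon, or in the aryl ring. Compound 1 `Cn1ncc(Cl)c1-c1cc(C(=O)N[C@@H]2CN[C@H](CC(O)CO)C[C@H]2c2ccc(Cl)c(Cl)c2)oc1Cl` in a functional assay on OVCAR-8 cells (Homo sapiens) for antiproliferative activity (a lower number here means a stronger inhibitor, a higher number a weaker inhibitor), gives 1610 nM. Compound 2 `Cn1ncc(Cl)c1-c1cc(C(=O)N[C@@H]2CNCC[C@H]2c2ccc(C(F)(F)F)cc2)oc1Cl`, which carries a trifluoromethyl-substituted ring instead, gives 120 nM. Compound 3 `C=CC[C@@H]1C[C@@H](c2ccc(Cl)c(Cl)c2)[C@H](NC(=O)c2cc(-c3c(Cl)cnn3C)c(Cl)o2)CN1` gives 990 nM, the second highest of the three numbers; its nearest neighbour is compound 1, and compound 2 lies furthest away.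

For the measured compounds named here, the only step touching this chain position, a 1.6-fold lower number from compound 1 to compound 3 (0.21 log units; within the scatter), stays within the scatter. Compound 4 `Cn1ncc(Cl)c1-c1cc(C(=O)N[C@@H]2CN[C@H](CC(=O)NC3CCC3)C[C@H]2c2ccc(Cl)c(Cl)c2)oc1Cl` carries the change (cyclobutylcarbamoyl in place of vinyl on a saturated chain carbon bound to a saturated ring carbon). Going by the values given here, since the one measured change at this position barely moved the number, little movement beyond the scatter is expected here either, though only one comparison supports that. Compound 4 is therefore estimated at 1000 nM, with a range of 350 nM to 3000 nM, meaning an expected step of a 1.0-fold higher number from compound 3 to compound 4 (0.00 log units; within the scatter).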

Compound 4, half-maximal inhibitory concentration: 610 nM
For compound 4 the middle estimate is 1.6-fold (0.21 log units) above the measured one; measured number inside the range.
By their numbers in this assay, from the lowest: compound 2; then compounds 4, 3 and 1 (each within the scatter of the next, the first and the last beyond it).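

Compound 4 shows that this chain position accepts a much bulkier group, one that brings a four-membered carbon ring and an amide, without a clear loss of activity in this assay: replacing the vinyl gives a step that stays within the scatter (a 1.6-fold lower number from compound 3 to compound 4 (0.21 log units; within the scatter)). For the compounds shown here, replacing the 1,2-dihydroxyethyl with the same cyclobutylcarbamoyl gives the first step at this position to pass the scatter, though only modestly (a 2.6-fold lower number from compound 1 to compound 4 (0.42 log units; beyond the scatter)). Nothing measured here explains either step.

As far as these compounds go, it remains open how a chain ending in an amine or a carboxylic acid, or an amide carrying a smaller or larger ring, would behave at this position. What the chain adds at all is also unresolved, since compound 2 differs from the others in more than one place.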